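This account rests on a few compounds, and the source may have more. Where it says the series, first, only, none or still open, it means among the compounds named here.

Working notes on the series. In an ADME assay on a cell-free system (plasma, Mus musculus) for metabolic stability, read by LC-MS, with a stated time of 60 min, tested at 10 uM (on this read-out higher numbers stand for a more stable compound and lower numbers for a less stable compound), compound 1 (`CCC(OC(=O)N[C@@H](CCC(=O)C=[N+]=[N-])C(=O)OC)OC(=O)C(C)(C)C`) gives 0%. Among the measured compounds shown here, compound 2 (`CC(C)C[C@H](N)C(=O)N[C@@H](CCC(=O)C=[N+]=[N-])C(=O)OC(C)C`) gives 0%, level with compound 1 within the usual scatter, and no measured compound stands apart from it.

Compound 3 (`CCOC(=O)[C@H](CCC(=O)C=[N+]=[N-])NC(=O)[C@@H](N)CC(C)C`) turns the isopropoxycarbonyl of compound 2 into ethoxycarbonyl: hydrogen in place of methyl on a saturated chain carbon bound to an oxygen next to a carbonyl group and a saturated chain carbon.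

For the measured compounds named here, no single-place step between measured compounds is available to size this change. In this assay no shift beyond the scatter is expected, in either direction, with compound 2 at 0% as the reference. The expected step of no change at the digits printed from compound 2 to compound 3 (within the scatter) stays within the scatter. For compound 3 the estimated value is 0%, with an expected range of 0% to 8%.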

Compound 3, percent of the compound remaining: 0%
The estimate for compound 3 equals the measured number at the digits printed, and the stated range covers the measured number.
By their numbers in this assay, from the lowest: compounds 1, 2 and 3 (each within the scatter of the next).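

In this assay, among the compounds shown here, the change from isopropoxycarbonyl to ethoxycarbonyl gives no change at the digits printed from compound 2 to compound 3 (within the scatter) and is the first single-place step. With nothing of either compound left on this read-out, the step shows only that replacing this methyl with hydrogen does not bring the value into a measurable range, and any difference in how the two compounds behave before the stated time remains unseen. Nothing shown here bears on the reason for this result. 

The compounds shown leave open whether any other group at this place would give a value different from that of compound 3, such as a tert-butoxycarbonyl, a longer chain such as butoxycarbonyl, a primary amide or a carboxylic acid. They also leave open whether a change elsewhere on the shared core would move the value.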